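A few compounds are considered here, and "the series" means these few. Any claim that something is new, unique, unknown or untested is made for them only; others in the source may bear on it.

Measured compounds:
Compound 1, `O=c1[nH]c2ccccc2cc1/C=N/O`: 2010000 nM
Compound 2, `Cc1ccc2[nH]c(=O)c(/C=N/O)cc2c1`: 1980000 nM
Compound 3, `O=C(O)c1ccc(/N=C/c2cc3ccccc3[nH]c2=O)cc1`: "not active" (no number reported)

In a functional assay, read by spectrophotometry, with a stated time of 1 h (a higher number here means a weaker inhibitor, a lower number a stronger inhibitor), compound 1 gives 2010000 nM and compound 2 gives 1980000 nM. The step of a 1.0-fold lower number from compound 1 to compound 2 (0.01 log units; within the scatter) is the change (methyl in place of hydrogen on an aromatic carbon). Compound 3 was reported in this assay as "not active" (no number reported), with no single number. The difference between the core of compound 1 and the core of compound 3 is not broken down here. Compound 4, `Cc1ccc2[nH]c(=O)c(/C=N/c3ccc(C(=O)O)cc3)cc2c1`, is not yet measured; it differs from compound 3 by methyl in place of hydrogen on an aromatic carbon, the same change as that from compound 1 to compound 2. Because a 1.0-fold lower number from compound 1 to compound 2 (0.01 log units; within the scatter) lies within the scatter, the same change on compound 3 is expected to leave the outcome essentially unchanged, so compound 4 is expected to remain very weak, and a reported limit rather than a number is likely. Compound 4 is estimated at 5000000 nM, between 1000000 nM and 30000000 nM.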

Compound 4, half-maximal inhibitory concentration: "not active" (no number reported)
For compound 4 the study gives words and no number, and the estimate cannot be compared.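

Compound 3 and compound 4 are both reported in words only, so no step can be read between them, and no evidence shown bears on this result. The compounds shown leave open whether methyl in place of hydrogen on an aromatic carbon alters activity on the core of compound 3.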